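The source may report more compounds than this note shows. Statements on the series, on what has been measured and on what is new or still open speak of the compounds shown alone.

Measured so far in a functional assay on PC-3 cells (Homo sapiens) for cytotoxicity, read by MTT assay, with a stated time of 72 h; on this read-out lower numbers stand for stronger inhibition and higher numbers for weaker inhibition:

- compound 1 `CNC(=O)c1cc(Oc2ccc(NC(=O)c3nccc(-c4ccccc4)n3)cc2)ccn1` gives 7310 nM
- compound 2 `CCc1ccc(-c2cc(C(=O)Nc3ccc(Oc4ccnc(C(=O)NC)c4)cc3)ncn2)cc1` gives 29300 nM
- compound 3 `CCc1ccc(-c2cc(C(=O)Nc3ccc(Oc4ccnc(C(=O)NC)c4)c(F)c3)ncn2)cc1` gives 15600 nM

Compound 1 has a lower number than compound 2, and that gap lies beyond the usual scatter. Compound 3, by contrast, cannot be told apart from compound 2.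

Compound 4 `CNC(=O)c1cc(Oc2ccc(NC(=O)c3cc(-c4ccc(F)cc4)ncn3)cc2)ccn1` has not yet been measured. Its difference from compound 2 is fluoro in place of ethyl on an aromatic carbon. Put simply, this is fluoro in place of ethyl on an aromatic carbon, para to a large group, which turns 4-ethylphenyl to 4-fluorophenyl.

Going by the values given here, only one measured step changes a single place: a 1.9-fold lower number from compound 2 to compound 3 (0.27 log units; within the scatter). It also brings in fluoro, but in place of hydrogen rather than ethyl, so it bears on this change only loosely. Compound 1, at 7310 nM, also carries no ethyl, yet it differs from compound 2 in other ways too, so it offers only a weak hint.

On these two loose hints, a modest move towards a lower number is expected in this assay. The expected change is a 2.0-fold lower number from compound 2 to compound 4 (0.29 log units; within the scatter). For compound 4 the estimated value is 15000 nM, with an expected range from 6000 nM to 35000 nM.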

Compound 4, half-maximal inhibitory concentration: > 100000 nM
Compound 4: only a limit was reported; the forecaster's own chance of this, stated with the estimate: 10%; middle value at least 6.6-fold (0.82 log units) away from the limit.
By their numbers in this assay, from the lowest: compound 1; then compounds 3 and 2 (each within the scatter of the next). At a limit, above all of these: compound 4.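

Compound 4 stands at a limit in this assay, not at a measured number: the limit of > 100000 nM in this assay, at which 1 of the 4 values shown sits.

Even so, the change from 4-ethylphenyl to 4-fluorophenyl gives an at least 3.4-fold higher number from compound 2 to compound 4 (0.53 log units; beyond the scatter), so the group on this aromatic carbon, para to a large group, makes a readable difference in this cell assay. Going by these compounds alone, the earlier compounds could not show this, since the only one-place step among them, a 1.9-fold lower number from compound 2 to compound 3 (0.27 log units; within the scatter), put fluoro in place of hydrogen at another place in the molecule and gave no change that could be told from scatter. Taken together, these two steps show that the effect of bringing in fluoro cannot be carried over from one place to another in this series.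

The compounds shown leave open whether the step at this position comes from losing the ethyl or from bringing in the fluoro, and the limit leaves its full size unknown as well. A plain hydrogen, a longer chain such as propyl, or an amine on this same carbon would help to separate these two readings.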